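This account rests on a few compounds, and the source may have more. Where it says the series, first, only, none or still open, it means among the compounds named here.

Measured so far in an ADME assay on HEK293 cells (Homo sapiens) for cytotoxicity, read by luminescence, with a stated time of 72 h; a higher number here means that more compound is needed for the effect, a lower number that less compound is needed:
- compound 1 `CCOC(=O)c1c(-c2cccc(OCC)c2)[nH]c2cc(OC)ccc2c1=O`: > 22000 nM
- compound 2 `CCOC(=O)c1c(-c2cccc(OCC(C)C)c2)[nH]c2cc(OC)ccc2c1=O`: > 22000 nM

Compound 1 gives only a limit of the assay in this assay, not a number. Compound 2 likewise gives only a limit. The step that the two limits leave unreadable from compound 1 to compound 2 is therefore unreadable, both values sitting at the limit of > 22000 nM in this assay, at which 2 of the 2 values shown sit. Compound 3 `CCOC(=O)c1c(-c2cccc(CO)c2)[nH]c2cc(OC)ccc2c1=O` differs from compound 1 by hydroxymethyl in place of ethoxy on an aromatic carbon. No readable step in the series bears on this change, so no direction beyond the limit can be drawn. The step that the limit leaves unreadable from compound 1 to compound 3 is expected to show no shift beyond the scatter. Compound 3 is expected to give 30000 nM, within 15000 nM to 80000 nM, most probably reported again as a limit.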

Compound 3, half-maximal effective concentration: > 22000 nM
Compound 3: a limit, no number (the forecaster's own chance of this, stated with the estimate: 80%); the middle value lies beyond the limit too.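

No step can be read among compound 1, compound 2 and compound 3, since all three rest on one shared limit: the limit of > 22000 nM in this assay, at which 3 of the 3 values shown sit. The compounds shown leave open whether ethoxy, isobutoxy and hydroxymethyl differ at all in effect on the shared core.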